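A chloro step from a compound at the limit

This account rests on a few compounds, and the source may have more. Where it says the series, first, only, none or still open, it means among the compounds named here.

Values in a toxicity assay on THP-1 cells (Homo sapiens) for inhibition (on this read-out higher numbers stand for lower toxicity in this test and lower numbers for higher toxicity in this test), each of them a limit:
- compound 1 `COc1ccc(-c2cnc(NC(=O)C3CCNCC3)n2C)cc1` gives > 100000 nM as a limit
- compound 2 `Cn1c(-c2ccccc2)cnc1NC(=O)c1ccccc1` gives > 100000 nM as a limit
- compound 3 `COc1ccc(-c2cnc(NC(=O)c3ccccc3)n2C)cc1` gives > 100000 nM as a limit

Compound 2 stands at a limit and not at a number. The set so far shows only the limit of > 100000 nM in this assay, at which 3 of the 3 values shown sit, and nothing else. Compound 4 `Cn1c(-c2ccccc2)cnc1NC(=O)c1cccc(Cl)c1` differs from compound 2 by chloro in place of hydrogen on an aromatic carbon, which is chloro in place of hydrogen on an aromatic carbon. Two measured changes bear on this, namely a step that the two limits leave unreadable from compound 2 to compound 3 and a step that the two limits leave unreadable from compound 1 to compound 3 and neither gives a size. No clear shift toward higher toxicity is therefore expected in this assay, and the expected change is a number no higher from compound 2 to compound 4 (the limit leaves the size open) as estimated here. For compound 4 the estimate is 100000 nM with an expected range from 30000 nM to 100000 nM in this estimate.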

Compound 4, half-maximal cytotoxic concentration: > 50000 nM
Compound 4 gave a limit, no number; the forecaster's own chance of this, stated with the estimate: 75%; the middle value is on the limit's open side.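

Compound 2 and compound 4 both sit at limits rather than numbers, so the step between them cannot be read. Going by these compounds, whether chloro in place of hydrogen changes toxicity in this test at all remains open.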